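The source may hold more compounds than are shown below. What is called first, only, known or untested is meant among the compounds shown, and "the series" means these compounds.

Compound 1 `Nc1nc(NC2CC2)c2ncn(/C=C3/CC3(CO)CO)c2n1`, compound 2 `CCCOc1nc(N)nc2c1ncn2/C=C1/CC1(CO)CO` and compound 3 `Nc1nc2c(ncn2/C=C2/CC2(CO)CO)c(=O)[nH]1` share one core and were all examined in an ADME assay on Akata cells (Homo sapiens) for cytotoxicity, with a stated time of 7 days; a higher number here means that more compound is tolerated, a lower number that less compound is tolerated. In this assay compound 1 gives > 20000 nM, which is a limit of the assay and not a number. For compound 2 this assay likewise records > 20000 nM, a limit. Compound 3 is recorded at > 20000 nM, again a limit. Compound 2 therefore stands at the same limit as the other two compounds, and the numbers shown do not separate them. Among the compounds with values here, the only step between measured compounds that differ in one place, a step that the two limits leave unreadable from compound 1 to compound 2, cannot be read; both of its ends are limits. Compound 4 `CN(C)c1nc(N)nc2c1ncn2/C=C1/CC1(CO)CO` differs from compound 2 by dimethylamino in place of propoxy on an aromatic carbon. Within the data shown here, no measured step bears on this change in a readable way; what the data offer is the limit of > 20000 nM in this assay, at which 3 of the 3 values shown sit, so that every compound of the series has been tolerated up to the top of the tested range. The estimated step is accordingly a number no higher from compound 2 to compound 4 (the limit leaves the size open), none beyond the scatter. Compound 4 is thus expected to give about 20000 nM in this assay, with a range from 10000 nM to 40000 nM, most likely again as a limit rather than a number.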

Compound 4, half-maximal cytotoxic concentration: > 24000 nM
Compound 4: a limit, no number; the forecaster's own chance of this, stated with the estimate: 85%; middle value at least 1.2-fold (0.07 log units) away from the limit.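

In this assay compound 4 is recorded at > 24000 nM, which is a limit of the assay and not a number. No new step can be read: compound 4 cannot be compared in size with compound 1 or compound 2, whose values are also limits. The compounds shown leave open at what concentration any of them would become cytotoxic.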